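This account rests on a few compounds, and the source may have more. Where it says the series, first, only, none or still open, it means among the compounds named here.

Measured so far:
compound 1, `O=C(CC1CCCC1)Nc1c(C(O)(C(F)(F)F)C(F)(F)F)ccc2ccccc12`, 81 nM
compound 2, `CC(C)OC(=O)Nc1c(C(O)(C(F)(F)F)C(F)(F)F)ccc2ccccc12`, 1160 nM
compound 3, `O=C(Nc1c(C(O)(C(F)(F)F)C(F)(F)F)ccc2ccccc12)c1cccc([N+](=O)[O-])c1`, 117 nM

All three share one core and differ only in the group on the carbonyl carbon of the amide-type nitrogen. In an assay on LtK cells with ATP-sensitive inward rectifier potassium channel 11 (Homo sapiens) as the target (on this read-out lower numbers stand for an effect already at smaller amounts and higher numbers for an effect only at larger amounts of compound), compound 3 gives 117 nM, the second highest of the three numbers. One step is a 1.4-fold higher number from compound 1 to compound 3 (0.16 log units; within the scatter), so the two cannot be told apart on this read-out; the other step is a 9.9-fold lower number from compound 2 to compound 3 (1.00 log units; beyond the scatter), and that one is clear.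

The unmeasured compound 4, `O=C(Nc1c(C(O)(C(F)(F)F)C(F)(F)F)ccc2ccccc12)c1cc(Cl)cc(Cl)c1`, differs from compound 3 as follows: 3,5-dichlorophenyl in place of 3-nitrophenyl on a carbonyl carbon.

For the measured compounds named here, none of the measured steps exchanges one substituent of an aryl amide for another. The step of a 1.4-fold higher number from compound 1 to compound 3 (0.16 log units; within the scatter) shows that an aryl group and a saturated chain on the carbonyl carbon give indistinguishable numbers, and a 9.9-fold lower number from compound 2 to compound 3 (1.00 log units; beyond the scatter) shows the large gap to the carbamate of compound 2. Since compound 4 keeps the aryl amide, the expected step is small: a 1.4-fold lower number from compound 3 to compound 4 (0.14 log units; within the scatter), with no direction beyond the scatter asserted. Compound 4 is therefore estimated at 85 nM, within the range 25 nM to 300 nM.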

Compound 4, half-maximal effective concentration: 306 nM
Compound 4: middle estimate off by 3.6-fold (0.56 log units), on the low side, outside the stated range (above it).
By their numbers in this assay, from the lowest: compounds 1 and 3 (each within the scatter of the next); then compound 4; then compound 2.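

Compound 4 shows that the aryl groups on this carbonyl carbon are not interchangeable: in this assay, 3,5-dichlorophenyl in place of 3-nitrophenyl gives a 2.6-fold higher number from compound 3 to compound 4 (0.42 log units; beyond the scatter), so a change confined to the aryl group is enough to move the number beyond the scatter. The earlier match between an aryl amide and the cyclopentylmethyl amide therefore holds for 3-nitrophenyl but does not extend to 3,5-dichlorophenyl, which gives a 3.8-fold higher number from compound 1 to compound 4 (0.58 log units; beyond the scatter), while the same group still stands clear of the isopropoxy carbamate, with a 3.8-fold lower number from compound 2 to compound 4 (0.58 log units; beyond the scatter), placing compound 4 in a middle position among these four compounds. Nothing available explains the difference between the two aryl groups.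

The compounds shown leave open whether the step between the two aryl amides follows the loss of the nitro group or the arrival of the two chlorine atoms, and a plain phenyl group or a phenyl group carrying a single chlorine atom on the carbonyl carbon would help separate the two. From the compounds shown here alone, it also remains open how an aryl group carrying an amine or a nitrile would fall relative to these numbers.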